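The source may report more compounds than this note shows. Statements on the series, on what has been measured and on what is new or still open speak of the compounds shown alone.

In an ADME assay on the whole organism (strain Sprague-Dawley) for pharmacokinetics, with Rattus norvegicus as the target, at a dose of 10 mg/kg by the oral route (on this read-out higher numbers stand for higher oral bioavailability and lower numbers for lower oral bioavailability), compound 1 (`CCCCNc1nc(N)nc2ccccc12`) gives 5.4%. Compound 2 (`CCCCNc1nc(N)nc2cccc(C(=O)N(C)Cc3ccccc3)c12`), which adds a benzyl(methyl)amino group on a carbonyl carbon to the shared core, gives 1.2%, so the two numbers lie within the usual scatter of each other. Compound 3 (`CCCCNc1nc(N)nc2cccc(C(=O)N[C@@H](C)c3ccccc3)c12`) has (1-phenylethyl)amino in place of benzyl(methyl)amino on a carbonyl carbon. Among the compounds with values here, no measured pair shows this kind of change, so the expectation rests on little. The estimated step, a number 3.8 percentage points higher from compound 2 to compound 3 (within the scatter), is expected to stay within the scatter. Compound 3 is expected to give 5%, with an estimated range from 1% to 20%.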

Compound 3, oral bioavailability: 20%
The estimate for compound 3 lay 15 percentage points below the measured number, and the stated range covers the measured number.
By their numbers in this assay, from the lowest: compounds 2 and 1 (each within the scatter of the next); then compound 3.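

Within this assay the swap of benzyl(methyl)amino for (1-phenylethyl)amino on a carbonyl carbon is worth a number 18.8 percentage points higher from compound 2 to compound 3 (beyond the scatter) and so shows that the read-out responds to how the same atoms are joined at this place. The entering group brings both the amide hydrogen and a defined stereocentre, and this single pair cannot tell these two changes apart. Nothing measured here explains the step. Still open, on these data alone, is whether plain benzylamino, which has the amide hydrogen but no stereocentre, or the mirror-image form of (1-phenylethyl)amino would behave the same way.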